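An Amino Group Enters a Compound Showing Only a Limit

The compounds below may be only part of what the source reports. "The series", "measured", "known", "first", "only" and "open" are said of these compounds alone.

Compound 2 `ClCc1ccccc1Cn1cnc2c(Cl)ncnc21` was tested in a functional assay on COLO 205 cells (Homo sapiens) for cytotoxicity, read by sulforhodamine B assay, with a stated time of 48 h; a higher number here means that more compound is tolerated, a lower number that less compound is tolerated. In this assay compound 2 reaches only the limit > 100000 nM, not a number. Compound 3 `ClCc1ccccc1Cn1cnc2ncnc(Cl)c21` likewise sits at the limit > 100000 nM. For compound 1 `ClCc1ccccc1Cn1cnc2c(Cl)nc(Cl)nc21` the entry is "not determined" (no result reported). Compound 2 thus stands among results that give no single number: the limit of > 100000 nM in this assay, at which 2 of the 3 values shown sit, plus one entry without a value. Going by the values given here, no step between measured compounds can be computed from these data. Compound 4 `Nc1nc(Cl)c2ncn(Cc3ccccc3CCl)c2n1` carries amino in place of hydrogen on an aromatic carbon, that is, amino in place of hydrogen on an aromatic carbon. With both measured values sitting at the limit of > 100000 nM in this assay, at which 2 of the 3 values shown sit, no step beyond the scatter is expected, and the expected step is a number no higher from compound 2 to compound 4 (the limit leaves the size open). Compound 4 is estimated at 100000 nM, with a range from 30000 nM to 300000 nM, most likely reported again as a limit.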

Compound 4, concentration lethal to 50% of the cells: > 100000 nM
Compound 4 ended at the assay's limit; the forecaster's own chance of this, stated with the estimate: 80%; the middle value sits exactly at the limit.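

In this assay compound 4 gives > 100000 nM, a limit and not a number. Going by these compounds alone, compound 2 gives > 100000 nM, also a limit, so no step between these two compounds can be read. The compounds shown leave open whether amino in place of hydrogen changes the read-out at all.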